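The compounds below may be only part of what the source reports. "The series", "measured", "known", "first", "only" and "open" are said of these compounds alone.

Three compounds have been measured in a functional assay on HeLa cells (Homo sapiens) for antiproliferative activity, read by CCK-8 assay, with a stated time of 72 h, tested at 8 uM; on this read-out lower numbers stand for a weaker effect and higher numbers for a stronger effect at the one concentration tested:

compound 1 `Nc1ccccc1NC(=O)c1ccc(CSC(=S)N2CCN(c3ccc(Cl)cc3)CC2)cc1`: 44.8%
compound 2 `Nc1ccccc1NC(=O)c1ccc(CSC(=S)N2CCc3cc([N+](=O)[O-])ccc32)cc1`: 43.6%
compound 3 `Nc1ccccc1NC(=O)c1ccc(CSC(=S)N2CCN(Cc3ccccc3)CC2)cc1`: 31.3%

Compound 2 stands second highest of these three numbers. Its nearest neighbour is compound 1, whose value lies within the scatter of its own, so the two cannot be told apart. Among the measured compounds shown here, compound 3 is furthest away, beyond the scatter, and the only measured step, a number 13.5 percentage points lower from compound 1 to compound 3 (beyond the scatter), concerns an amine nitrogen in a ring of compound 1 and compound 3, a part of the molecule that compound 4 `COC(=O)c1ccc2c(c1)CCN2C(=S)SCc1ccc(C(=O)Nc2ccccc2N)cc1` does not share. Compound 4 differs from compound 2 by methoxycarbonyl in place of nitro on an aromatic carbon. For the measured compounds named here, no measured step touches this aromatic carbon, so nothing anchors a direction; the expected step is a number 3.6 percentage points lower from compound 2 to compound 4 (within the scatter), within the scatter. Compound 4 is therefore estimated at 40%, in a range from 28% to 52%.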

Compound 4, a percentage reported as inhibition, at one concentration (the size of the read-out at that concentration, not a potency): 60.1%
Compound 4: middle estimate off by 20.1 percentage points, on the low side, and the stated range ends below it.
By their numbers in this assay, from the lowest: compound 3; then compounds 2 and 1 (each within the scatter of the next); then compound 4.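

Swapping nitro for methoxycarbonyl on this aromatic carbon gives a number 16.5 percentage points higher from compound 2 to compound 4 (beyond the scatter) in this assay, so this position, untouched by the earlier steps, clearly affects the read-out. The two groups have the same counts of hydrogen-bond donors and acceptors, so those counts do not separate them. No available evidence bears on the reason for this step. Going by these compounds, whether a carboxylic acid or an amine on this carbon would raise or lower the number remains open. So does whether a methyl ketone would match methoxycarbonyl here.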